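Replacing (ethoxycarbonyl)methyl with 4-chlorophenyl on the amine nitrogen

This account rests on a few compounds, and the source may have more. Where it says the series, first, only, none or still open, it means among the compounds named here.

Compound 2 `CCOC(=O)CNc1ncc([N+](=O)[O-])c(N(CC(=O)OCC)Cc2ccccc2)n1` carries (ethoxycarbonyl)methyl on the ring-bound nitrogen of the shared core. In a functional assay on A549 cells (Homo sapiens) for antiproliferative activity, read by MTT assay, with a stated time of 48 h (a higher number here means a weaker inhibitor, a lower number a stronger inhibitor), compound 2 gives > 100000 nM, which is a limit of the assay and not a number. Among the measured compounds shown here, compound 1 `CCOC(=O)CN(Cc1ccccc1)c1nc(Nc2cc(OC)c(OC)c(OC)c2)ncc1[N+](=O)[O-]` is the only other measured member. In this assay compound 1 gives > 100000 nM, likewise a limit. The step that the two limits leave unreadable from compound 1 to compound 2 stays unreadable because of the limit of > 100000 nM in this assay, at which 2 of the 2 values shown sit. Compound 3 `CCOC(=O)CN(Cc1ccccc1)c1nc(Nc2ccc(Cl)cc2)ncc1[N+](=O)[O-]` differs from compound 2 by 4-chlorophenyl in place of (ethoxycarbonyl)methyl on a nitrogen on an aromatic ring. For the measured compounds named here, no measured step bears on this change, since compound 1 also sits at the limit with an aryl group on the same nitrogen. The expectation therefore rests only on both measured members sitting at the limit: compound 3 is estimated at 100000 nM, within 20000 nM to 300000 nM. The estimated step of a number no higher from compound 2 to compound 3 (the limit leaves the size open) is expected to stay within the scatter, with a limit again the likely outcome.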

Compound 3, half-maximal inhibitory concentration: > 100000 nM
Compound 3: only a limit was reported (the forecaster's own chance of this, stated with the estimate: 70%); the middle value lies on the limit itself.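

No step among compound 1, compound 2 and compound 3 can be read, because each result is a limit and not a number: the limit of > 100000 nM in this assay, at which 3 of the 3 values shown sit.

The compounds shown leave open whether (ethoxycarbonyl)methyl, 4-chlorophenyl or 3,4,5-trimethoxyphenyl on this nitrogen makes any difference in this assay.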